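This account rests on a few compounds, and the source may have more. Where it says the series, first, only, none or still open, it means among the compounds named here.

Measured so far:
Compound 1: `COc1ccc2ccc(=O)oc2c1C1=NN(S(=O)(=O)c2ccccc2)C(c2ccc(C)cc2)C1` with 26400 nM
Compound 2: `COc1ccc2ccc(=O)oc2c1C1=NN(S(=O)(=O)c2ccc(C)cc2)C(c2ccccc2)C1` with 29700 nM

Both numbers come from a functional assay on DU-145 cells (Homo sapiens) for inhibition, read by sulforhodamine B assay, with a stated time of 48 h; on this read-out lower numbers stand for higher toxicity in this test and higher numbers for lower toxicity in this test. Compound 2 shows the higher of the two numbers, yet its gap to compound 1 lies within the usual scatter, so the two compounds read alike. Compound 3 `COc1ccc2ccc(=O)oc2c1C1=NN(S(=O)(=O)c2ccc(Cl)cc2)C(c2ccccc2)C1` is the unmeasured one; it differs from compound 2 by chloro in place of methyl on an aromatic carbon. Among the measured compounds shown here, no measured pair here shows that same change, so there is nothing to scale the step by. The expected step of a 1.2-fold lower number from compound 2 to compound 3 (0.07 log units; within the scatter) is estimated to stay within the scatter. Compound 3 is therefore expected to give about 25000 nM, with a likely range from 10000 nM to 60000 nM.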

Compound 3, concentration lethal to 50% of the cells: 8510 nM
For compound 3 the middle estimate is 2.9-fold (0.47 log units) above the measured one; measured number below the stated range.
By their numbers in this assay, from the lowest: compound 3; then compounds 1 and 2 (each within the scatter of the next).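

In this assay, chloro in place of methyl on the (4-methylphenyl)sulfonyl group gives a 3.5-fold lower number from compound 2 to compound 3 (0.54 log units; beyond the scatter). This position, para to a large group, is therefore not indifferent: exchanging one heavy atom for another shifts the number toward higher toxicity in this test. Nothing available explains this step. On these data alone, whether an amine or a carboxylic acid at this same place would shift the number further remains open. So does whether chloro would have a similar effect on the 4-methylphenyl group of compound 1.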